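Phenyl to 4-chlorophenyl on compound 2

A few compounds are considered here, and "the series" means these few. Any claim that something is new, unique, unknown or untested is made for them only; others in the source may bear on it.

Measured in a functional assay on MCF7 cells (Homo sapiens) for cytotoxicity, read by MTT assay, with a stated time of 72 h; a higher number here means a weaker inhibitor, a lower number a stronger inhibitor:
- compound 1 `COc1ccc(-c2ccc(C(=O)Nc3ccc(Oc4ccnc5[nH]ccc45)cc3)nc2)cc1`: > 10000 nM
- compound 2 `O=C(Nc1ccc(Oc2ccnc3[nH]ccc23)c(F)c1)c1ccc(-c2ccccc2)cn1`: 4390 nM

Compound 1 gives > 10000 nM, which is a limit of the assay and not a number. Among the measured compounds shown here, compound 2, at 4390 nM, therefore holds the only true number so far, and it offers no measured step to reason from.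

Compound 3 `O=C(Nc1ccc(Oc2ccnc3[nH]ccc23)c(F)c1)c1ccc(-c2ccc(Cl)cc2)cn1` goes from phenyl to 4-chlorophenyl on compound 2: chloro in place of hydrogen on an aromatic carbon, para to a large group. For the measured compounds named here, no measured pair covers this change, so only a modest shift in this assay is expected, near the edge of the scatter and leaning towards a lower number. The expected change is a 1.5-fold lower number from compound 2 to compound 3 (0.17 log units; within the scatter). For compound 3 the estimated value is 3000 nM, with an expected range of 1000 nM to 9000 nM.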

Compound 3, half-maximal inhibitory concentration: > 10000 nM
Compound 3: a limit, no number; the forecaster's own chance of this, stated with the estimate: 15%; middle value at least 3.3-fold (0.52 log units) away from the limit.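

In this assay, among the compounds shown here, chloro in place of hydrogen on an aromatic carbon, para to a large group, is the first single change that can be read, and it gives an at least 2.2-fold higher number from compound 2 to compound 3 (0.35 log units; beyond the scatter). Compound 3 gives > 10000 nM, which is a limit of the assay and not a number. This position therefore responds to a single added chlorine, but the step is only a lower bound on the change, and its full size cannot be read: the limit of > 10000 nM in this assay, at which 2 of the 3 values shown sit.

The compounds shown leave open whether this loss is specific to chloro or extends to other groups at the same position, such as an amine or a carboxylic acid. Compound 1 differs from compound 2 in more than one place, so it gives no clean reading of this position.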